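Acetyl in place of methyl on the shared core

The source may report more compounds than this note shows. Statements on the series, on what has been measured and on what is new or still open speak of the compounds shown alone.

Compound 1: `O=C(CCCCCCc1ccccc1)c1nc(Cl)co1`, 4 nM
Compound 2: `Cc1coc(C(=O)CCCCCCc2ccccc2)n1`, 520 nM

Both compounds were tested in an assay on isolated protein for inhibition of Fatty-acid amide hydrolase 1 (Rattus norvegicus); a higher number here means a weaker inhibitor, a lower number a stronger inhibitor. For the measured compounds named here, compound 1 gives 4 nM and compound 2 gives 520 nM, so compound 2 has the higher of the two numbers and is the weaker inhibitor of the pair; the only measured step, a 130-fold higher number from compound 1 to compound 2 (2.11 log units; beyond the scatter), separates them. Compound 3, `CC(=O)c1coc(C(=O)CCCCCCc2ccccc2)n1`, is not yet measured. It differs from compound 2 in one place: acetyl in place of methyl on an aromatic carbon. Going by the values given here, the one measured step bears on this change only loosely. It shows that the group on this aromatic carbon matters a great deal: the chloro-to-methyl exchange moved the number far. Acetyl is neither of those groups, and no measured pair shows what acetyl does here. Because the exchange on this aromatic carbon was so large in a 130-fold higher number from compound 1 to compound 2 (2.11 log units; beyond the scatter), a sizeable move in this assay is expected for compound 3, most likely back toward a lower number. Compound 3 is estimated to give 10 nM, within 2 nM to 60 nM, meaning a step of a 52-fold lower number from compound 2 to compound 3 (1.72 log units; beyond the scatter).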

Compound 3, inhibition constant: 2 nM
Compound 3: the middle estimate sits 5.0-fold (0.70 log units) above what was measured; measured number inside the range.
By their numbers in this assay, from the lowest: compounds 3 and 1 (each within the scatter of the next); then compound 2.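

At this aromatic carbon, the change from methyl to acetyl in this assay gives a very large step (a 260-fold lower number from compound 2 to compound 3 (2.41 log units; beyond the scatter)), which shows that the weak number of compound 2 is not a general feature of the shared core. The step between the other two compounds (a 2.0-fold lower number from compound 1 to compound 3 (0.30 log units; within the scatter)) leaves chloro and acetyl indistinguishable here, so this position accepts acetyl, with its three heavy atoms and its hydrogen-bond acceptor, as well as it accepts chloro, and among these three compounds only methyl stands apart. Nothing measured explains why methyl differs so much from the other two groups, and no outside evidence bears on this result.

The compounds shown cannot separate the contribution of the acetyl carbonyl from that of the extra carbons, and a comparison with ethyl, which has carbon atoms only, or with a nitrile or a methyl ester could begin to do so. As far as these compounds go, it also remains open how a plain hydrogen, a bromo group or an amine at this carbon would compare, and whether the same order of groups would hold with a shorter or longer chain on the other side of the core.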